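This account rests on a few compounds, and the source may have more. Where it says the series, first, only, none or still open, it means among the compounds named here.

Compound 1 `COC(=O)c1cc(O)ccc1OC(=O)COc1cc(O)c2c(=O)cc(-c3ccccc3)oc2c1` is one of two compounds that have been tested in a functional assay on cells (T-cell, Mus musculus, strain BALB/c) for inhibition, read by MTT assay, with a stated time of 72 h; on this read-out lower numbers stand for stronger inhibition and higher numbers for weaker inhibition. In this assay compound 1 gives 29500 nM, the lowest number of the two recorded, although the margin is within the usual scatter. Compound 2 `COC(=O)c1c(Cl)cc(Cl)cc1OC(=O)COc1cc(O)c2c(=O)cc(-c3ccccc3)oc2c1` differs from compound 1 in more than one place, and in this assay compound 2 gives 43600 nM, a number that cannot be separated from that of compound 1. Compound 3 `COC(=O)c1ccccc1OC(=O)COc1cc(O)c2c(=O)cc(-c3ccccc3)oc2c1` has not yet been measured. It differs from compound 1 in a single place: hydrogen in place of hydroxy on an aromatic carbon. For the measured compounds named here, no step between two measured compounds probes this kind of change, so the expectation rests on compound 1 alone. The step from compound 1 to compound 3 is expected to be a 1.2-fold higher number from compound 1 to compound 3 (0.09 log units; within the scatter), a move not clearly beyond the scatter in either direction. Compound 3 is therefore estimated at 36000 nM, with a range from 12000 nM to 110000 nM.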

Compound 3, half-maximal inhibitory concentration: 28500 nM
The estimate for compound 3 lay 1.3-fold (0.10 log units) above the measured number; measured number inside the range.
By their numbers in this assay, from the lowest: compounds 3, 1 and 2 (each within the scatter of the next).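

In this assay the change reads a 1.0-fold lower number from compound 1 to compound 3 (0.01 log units; within the scatter) for hydrogen in place of hydroxy on this aromatic carbon, meta to the methoxycarbonyl group and para to the large group. For the compounds shown here, compound 1 and compound 2 differ in more than one place, so this is the first single-place reading of the position. It shows that the hydroxy group can be replaced by hydrogen here without a difference that stands out from the scatter.

As far as these compounds go, it remains open whether an amine, a methoxy group or a carboxylic acid at this position would read the same way, or whether the same replacement would read the same way with other groups on this ring. Nothing at hand bears on the reason for this result.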